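Amide-nitrogen substituent changes on a shared core: compound 4

The source may hold more compounds than are shown below. What is called first, only, known or untested is meant among the compounds shown, and "the series" means these compounds.

Measured compounds:
- compound 1 `CCn1c(C(=O)NCCN)ccc1C(CC)(CC)c1ccc(OCCC(O)(CC)CC)c(C)c1`; in a functional assay on PC-3 cells (Homo sapiens) for antiproliferative activity, read by MTT assay, with a stated time of 48 h (a higher number here means a weaker inhibitor, a lower number a stronger inhibitor), compound 1 gives 2420 nM.
- compound 2 `CCn1c(C(=O)Nc2cccc(C(F)(F)F)c2)ccc1C(CC)(CC)c1ccc(OCCC(O)(CC)CC)c(C)c1`; in this assay compound 2 gives 23800 nM.
- compound 3 `CCC(C)C(NC(=O)c1ccc(C(CC)(CC)c2ccc(OCCC(O)(CC)CC)c(C)c2)n1CC)C(=O)OC`; in this assay compound 3 gives > 50000 nM, which is a limit of the assay and not a number.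

Compound 1 stands at the lowest of the two numbers in this assay; the nearest is a 9.8-fold higher number from compound 1 to compound 2 (0.99 log units; beyond the scatter). Compound 3 only reaches (the limit of > 50000 nM in this assay, at which 1 of the 3 values shown sits).

Compound 4 `CCn1c(C(=O)NC(C)C(=O)O)ccc1C(CC)(CC)c1ccc(OCCC(O)(CC)CC)c(C)c1` differs from compound 1 in one place: 1-carboxyethyl in place of 2-aminoethyl on an amide-type nitrogen. Both measured steps away from compound 1 alter the group on this same amide-type nitrogen: a 9.8-fold higher number from compound 1 to compound 2 (0.99 log units; beyond the scatter) and an at least 20-fold higher number from compound 1 to compound 3 (1.31 log units; beyond the scatter); the two replacements are set against each other by an at least 2.1-fold higher number from compound 2 to compound 3 (0.32 log units; beyond the scatter). Every change made so far at this position has given a higher number in this assay. The entering 1-carboxyethyl group is smaller than the group of compound 3 and carries no ring, so a step of intermediate size in the same direction is expected: a 6.2-fold higher number from compound 1 to compound 4 (0.79 log units; beyond the scatter). Compound 4 is estimated at 15000 nM, with a range from 4000 nM to 50000 nM.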

Compound 4, half-maximal inhibitory concentration: 11700 nM
Estimate against measurement, compound 4: 1.3-fold (0.11 log units) above; the measured number falls inside the stated range.
By their numbers in this assay, from the lowest: compound 1; then compound 4; then compound 2. At a limit, above all of these: compound 3.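

Replacing 2-aminoethyl with 1-carboxyethyl on this amide-type nitrogen still raises the number, with a 4.8-fold higher number from compound 1 to compound 4 (0.68 log units; beyond the scatter), yet the same group also improves on the 3-(trifluoromethyl)phenyl group, with a 2.0-fold lower number from compound 2 to compound 4 (0.31 log units; beyond the scatter), so compound 1 keeps the lowest number and replacements at this position are not all equivalent. Lacking a ring does not by itself settle the outcome, as the ring-free group of compound 3 goes against any such reading, with an at least 4.2-fold lower number from compound 3 to compound 4 (0.63 log units; beyond the scatter). Compound 3 is held at a limit of the assay and not a number: the limit of > 50000 nM in this assay, at which 1 of the 4 values shown sits.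

Still open, as far as these compounds go, is how a longer amine chain such as 3-aminopropyl, or a 2-hydroxyethyl group, would compare with 2-aminoethyl on this nitrogen. Also open, from the compounds shown here alone, is whether the methyl ester of 1-carboxyethyl would stand nearer compound 4 or compound 3.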